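The source may report more compounds than this note shows. Statements on the series, on what has been measured and on what is new or still open speak of the compounds shown alone.

The shared core of these compounds carries benzyloxy groups, a (benzyloxy)methyl group and a free hydroxy group; what changes is the substituent on the saturated ring carbon next to the ring oxygen. Compound 1 `C=C[C@@H]1O[C@H](COCc2ccccc2)[C@@H](OCc2ccccc2)[C@H](OCc2ccccc2)[C@H]1O` bears a vinyl group there. Among the compounds with values here, in a functional assay on HL-60 cells (Homo sapiens) for antiproliferative activity, read by MTT assay (on this read-out higher numbers stand for weaker inhibition and lower numbers for stronger inhibition), compound 1 gives 11800 nM, the only number among the measured compounds. Compound 2 `CCCC[C@H]1O[C@H](COCc2ccccc2)[C@@H](OCc2ccccc2)[C@H](OCc2ccccc2)[C@H]1O` carries a butyl group in the same place, and in this assay compound 2 is reported as "not active" (no number reported), with no number given. Taken together, the two values show that replacing the vinyl group by a chain loses even the weak inhibition seen with compound 1. Compound 3 `O[C@@H]1[C@@H](OCc2ccccc2)[C@H](OCc2ccccc2)[C@@H](COCc2ccccc2)O[C@H]1c1ccccc1` is the unmeasured member; it differs from compound 1 in one place: phenyl in place of vinyl on a saturated ring carbon. Within the data shown here, no step between measured compounds is available, so the size of this change has to be judged from the two values alone. The expected step of a 1.4-fold higher number from compound 1 to compound 3 (0.13 log units; within the scatter) is small, leaning toward weaker inhibition, and may not exceed the usual scatter. Compound 3 is therefore expected to give about 16000 nM, between 4000 nM and 60000 nM.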

Compound 3, half-maximal inhibitory concentration: 26300 nM
Compound 3: middle estimate off by 1.6-fold (0.22 log units), on the low side; the measured number falls inside the stated range.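

In this assay, within the data shown here, the change from vinyl to phenyl on this saturated ring carbon gives a 2.2-fold higher number from compound 1 to compound 3 (0.35 log units; beyond the scatter) and so supplies the first step at this position that can be read as a number, a modest one toward weaker inhibition. Compound 3 still gives a number while compound 2, with butyl in the same place, is reported as not active, so among these three compounds a group with an aromatic ring keeps a measurable effect that the butyl chain does not, though that effect remains weaker than the one seen with vinyl. Nothing available here accounts for the difference between phenyl and vinyl at this position.

Still open, going by these compounds, is how this position responds to groups containing atoms other than carbon, such as an amine, a carboxylic acid or a pyridine ring, and whether a shorter chain such as ethyl or a chlorophenyl group would move the number in either direction. On these data alone, the benzyloxy groups, the (benzyloxy)methyl group and the hydroxy group stay the same throughout, so their contribution to the activity of the shared core also remains unknown.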